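Adding a Methoxy Group to Compound 2

A few compounds are considered here, and "the series" means these few. Any claim that something is new, unique, unknown or untested is made for them only; others in the source may bear on it.

Compound 1 `COc1cc(CCCCC(=O)/C=C/c2ccc(O)cc2)ccc1O`: 67%
Compound 2 `Oc1ccc(CCCCC(O)CCc2ccc(O)cc2)cc1`: 43%
Compound 3 `O=C(CCCCc1ccc(O)cc1)CCc1ccc(O)cc1`: 43%

In an ADME assay on HT-22 cells (Mus musculus) for cytotoxicity, read by MTT assay, with a stated time of 24 h, tested at 10 uM (on this read-out lower numbers stand for a stronger effect and higher numbers for a weaker effect at the one concentration tested), compound 2 gives 43%, level with compound 3 at the digits shown, the two together the lowest of the three numbers, while compound 1 stands higher by a margin beyond the scatter. Compound 4 `COc1cc(CCC(O)CCCCc2ccc(O)cc2)ccc1O` has not yet been measured. It differs from compound 2 by methoxy in place of hydrogen on an aromatic carbon. Among the compounds with values here, no measured pair isolates this single change, so its effect on its own is unknown here. Compound 1 also carries a methoxy group, but it differs from compound 2 in other places as well, so its higher number cannot be credited to that group alone. A modest step, upward or none beyond the scatter, is expected a number 7 percentage points higher from compound 2 to compound 4 (within the scatter). Compound 4 is therefore estimated at 50%, in a range from 35% to 65%.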

Compound 4, a percentage reported as activity, at one concentration (the size of the read-out at that concentration, not a potency): 75%
Compound 4: middle estimate off by 25 percentage points, on the low side; the whole stated range lies below it.
By their numbers in this assay, from the lowest: compounds 2 and 3 (each within the scatter of the next); then compounds 1 and 4 (each within the scatter of the next).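

In this assay, methoxy in place of hydrogen on this aromatic carbon, ortho to a hydroxy group, gives a number 32 percentage points higher from compound 2 to compound 4 (beyond the scatter). Within the data shown here, this is the first pair to isolate the change, and it shows that this single small group is enough to weaken the effect at the one concentration tested. Nothing here explains why the step is so large.

From the compounds shown here alone, it remains open whether the step is particular to methoxy or would also appear with an ethoxy group or a chlorine atom on the same carbon.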